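A Cyclopropyl Amide on a Shared Diaryl Ether Core

The source may hold more compounds than are shown below. What is called first, only, known or untested is meant among the compounds shown, and "the series" means these compounds.

Compound 3 `CN(C)C(=O)CCc1ccc(NCc2cccc(Oc3ccccc3)c2)cc1` carries a 2-(dimethylcarbamoyl)ethyl group on the shared core and gives 174 nM in a functional assay on CHO cells for agonist activity at Free fatty acid receptor 1 (Homo sapiens); a higher number here means that more compound is needed for the effect, a lower number that less compound is needed. Among the two numbers that exist, compound 3 has the highest; its nearest neighbour is compound 2 `O=C(O)/C=C/c1ccc(NCc2cccc(Oc3ccccc3)c2)cc1`, which gives 145 nM, and the step of a 1.2-fold higher number from compound 2 to compound 3 (0.08 log units; within the scatter) lies within the scatter. Compound 1 `O=C(O)c1ccc(NCc2cccc(Oc3ccccc3)c2)cc1` gives < 10000 nM in this assay, which is a limit of the assay rather than a number. Because of the limit of < 10000 nM in this assay, at which 1 of the 3 values shown sits, the steps a step that the limit leaves unreadable from compound 1 to compound 2 and a step that the limit leaves unreadable from compound 1 to compound 3 cannot be sized.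

Compound 4 `CC(C)NC(=O)[C@H]1C[C@@H]1c1ccc(NCc2cccc(Oc3ccccc3)c2)cc1` has not yet been measured. It differs from compound 3 in one place: 2-(isopropylcarbamoyl)cyclopropyl in place of 2-(dimethylcarbamoyl)ethyl on an aromatic carbon. Among the measured compounds shown here, no measured step covers this exchange. For the measured compounds named here, the only readable step, a 1.2-fold higher number from compound 2 to compound 3 (0.08 log units; within the scatter), swaps one side chain for another on the same aromatic carbon and stays within the scatter, so the two numbers that exist sit close together. The author therefore expects the step of a 1.2-fold lower number from compound 3 to compound 4 (0.06 log units; within the scatter) to remain within or close to the scatter, with no clear direction. Compound 4 is estimated to give 150 nM in this assay, with a range from 45 nM to 500 nM.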

Compound 4, half-maximal effective concentration: 12.6 nM
The estimate for compound 4 lay 12-fold (1.08 log units) above the measured number; the whole stated range lies above it.
By their numbers in this assay, from the lowest: compound 4; then compounds 2 and 3 (each within the scatter of the next).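

Up to this point, the two side chains with numbers at this aromatic carbon, para to a large group, stood within the scatter of each other, so the position had shown little response to a change of side chain. In this assay, 2-(isopropylcarbamoyl)cyclopropyl in place of 2-(dimethylcarbamoyl)ethyl now gives a 14-fold lower number from compound 3 to compound 4 (1.14 log units; beyond the scatter), showing that this position can respond strongly to the group it carries. The same group in place of 2-carboxyethenyl gives a 12-fold lower number from compound 2 to compound 4 (1.06 log units; beyond the scatter), so among the compounds shown a carboxylic acid is not required at this position for a low number, and the step from compound 1 to compound 4 cannot be read: the limit of < 10000 nM in this assay, at which 1 of the 4 values shown sits.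

The change brings in the three-membered ring, the amide hydrogen, the isopropyl group and the two defined stereocentres together, and the compounds shown do not separate their contributions. On these data alone, a 2-(isopropylcarbamoyl)ethyl chain, a cyclopropyl ring bearing dimethylcarbamoyl or a carboxylic acid, and the other stereoisomers of the cyclopropyl amide would each bear on that question, and their numbers remain open.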